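This account rests on a few compounds, and the source may have more. Where it says the series, first, only, none or still open, it means among the compounds named here.

Working notes on the series. Compound 1 `COc1cc(OC)c2c(=O)cc(-c3ccc(OCCBr)cc3)oc2c1` gives "not active" (no number reported) in a functional assay (Homo sapiens) for antiproliferative activity, read by resazurin assay, with a stated time of 48 h, tested at 10 uM (a higher number here means a stronger effect of the compound at the concentration tested, a lower number a weaker effect), with no number attached to it. Compound 2 `COc1cc(OC)c2c(=O)cc(-c3ccc(OCCN4CCCC4=O)cc3)oc2c1` gives 14% in this assay. Compound 3 `COc1cc(OC)c2c(=O)cc(-c3ccc(OCC(O)CN4CCCC4)cc3)oc2c1` gives 37% in this assay, the higher of the two numbers available; the step of a number 23 percentage points higher from compound 2 to compound 3 (beyond the scatter) lies beyond the scatter. Compound 4 `COc1cc(OC)c2c(=O)cc(-c3ccc(OCC(O)CO)cc3)oc2c1` has not yet been measured in this assay. It differs from compound 3 in one place: hydroxy in place of pyrrolidin-1-yl on a saturated chain carbon, two bonds along the chain from an oxygen on a saturated carbon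

For the measured compounds named here, only one measured step bears on this position, and it brought in the hydroxy and the pyrrolidin-1-yl together, so it does not separate the two; no measured step removes the pyrrolidin-1-yl on its own. With the pyrrolidin-1-yl gone, the number for compound 4 is expected to fall back toward that of compound 2, a downward step a number 22 percentage points lower from compound 3 to compound 4 (beyond the scatter) of modest size, with the retained hydroxy leaving this uncertain. Compound 4 is estimated at 15%, expected between 0% and 35%.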

Compound 4, a percentage reported as inhibition, at one concentration (the size of the read-out at that concentration, not a potency): 11%
Beside the measured number, compound 4's estimate is 4 percentage points above it; the measured number falls inside the stated range.
By their numbers in this assay, from the lowest: compounds 4 and 2 (each within the scatter of the next); then compound 3.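

Exchanging the 2-hydroxy-3-(pyrrolidin-1-yl)propyl for 2,3-dihydroxypropyl gives a number 26 percentage points lower from compound 3 to compound 4 (beyond the scatter) in this assay and so separates what the earlier step had joined: the chain hydroxy, present in both compounds, does not on its own hold the number of compound 3, and the read-out here depends on the pyrrolidin-1-yl. Against the (2-oxopyrrolidin-1-yl)methyl, the 1,2-dihydroxyethyl gives a number 3 percentage points lower from compound 2 to compound 4 (within the scatter) and so is not told apart from it in this assay by this read-out.

Still open, as far as these compounds go, is whether the pyrrolidin-1-yl can give way to another amine on the same carbon, such as piperidin-1-yl, morpholin-4-yl or dimethylamino. Also open, from the compounds shown here alone, is whether the pyrrolidin-1-yl holds the number on a plain ethyl chain without the hydroxy. No measurement on hand accounts for these steps.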